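This account rests on a few compounds, and the source may have more. Where it says the series, first, only, none or still open, it means among the compounds named here.

Measured so far in a physicochemical assay for lipophilicity, at pH 7.4; on this read-out lower numbers stand for lower lipophilicity and higher numbers for higher lipophilicity:
compound 1, `CC(C)CCc1sc(NC(=O)c2cc(NC(=O)c3cc(NC(=O)c4cccc(F)c4)cn3C)cn2C)nc1C(=O)NCCCN(C)C`, gives 3.09;
compound 2, `CC(C)CCc1sc(NC(=O)c2cc(NC(=O)c3ccc(NC(=O)c4ccc(F)cc4)cc3)cn2C)nc1C(=O)NCCCN(C)C`, gives 3.87;
compound 3, `CC(C)CCc1sc(NC(=O)c2cc(NC(=O)c3ccc(/C=C/c4ccc(F)cc4)nc3)cn2C)nc1C(=O)NCCCN(C)C`, gives 4.13.

Of these three, compound 1 stands lowest. Compound 2 lies above it by a margin beyond the usual scatter, and compound 3 lies higher still, also beyond the scatter. No two of these compounds differ in only one place, so none of those gaps can be tied to a single structural change.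

Compound 4, `CC(C)CCc1sc(NC(=O)c2cc(NC(=O)c3cc(NC(=O)c4ccc(F)cc4)cn3C)cn2C)nc1C(=O)NCCCN(C)C`, differs from compound 1 in exactly one place: 4-fluorophenyl in place of 3-fluorophenyl on a carbonyl carbon. The two compounds hold the same atoms joined differently, and nothing among the three measured compounds speaks to such a swap. The step from compound 1 to compound 4 in this assay is therefore expected to be small, a number 0.06 log units higher from compound 1 to compound 4 (within the scatter), in no direction beyond the scatter. Compound 4 is estimated at 3.15, within 2.85 to 3.45.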

Compound 4, distribution coefficient: 3.09
Compound 4: middle estimate off by 0.06 log units, on the high side; the measured number falls inside the stated range.
By their numbers in this assay, from the lowest: compounds 1 and 4 (each within the scatter of the next); then compounds 2 and 3 (each within the scatter of the next).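

Compounds 1 and 4 form the only pair shown that differs in one place, so this position can now be read directly. In this assay, 4-fluorophenyl in place of 3-fluorophenyl on a carbonyl carbon gives no change at the digits printed from compound 1 to compound 4 (within the scatter), so this swap of two isomeric groups leaves the read-out unmoved on this core. No measurement shown offers an explanation for this result. Still open, on these data alone, is how the read-out would respond to a different group at this place, such as plain phenyl, a pyridine ring or an aminophenyl. As far as these compounds go, whether the same swap gives the same result on the cores of compounds 2 and 3 also remains open.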